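Replacing the Piperidin-3-yl Arm: Compound 2 to Compound 3

The source may report more compounds than this note shows. Statements on the series, on what has been measured and on what is new or still open speak of the compounds shown alone.

Measured so far:
compound 1, `c1ccc2c(c1)CN[C@@H](CN(CC[C@H]1CCCNC1)[C@H]1CCCc3cccnc31)C2`; in an ADME assay on microsomes from liver (Homo sapiens) for metabolic stability, read by LC-MS, with a stated time of 10 min, tested at 0.5 uM (on this read-out lower numbers stand for a less stable compound and higher numbers for a more stable compound), compound 1 gives 93%
compound 2, `c1ccc2c(c1)CN[C@@H](CN(CC[C@@H]1CCCNC1)[C@H]1CCCc3cccnc31)C2`; in this assay compound 2 gives 75%

Compound 2 stands lowest of the two numbers in this assay. Among the measured compounds shown here, the only measured step is a number 18 percentage points lower from compound 1 to compound 2 (beyond the scatter), and it rests on (the fact that compounds 1 and 2 differ only in the configuration as drawn). Compound 3, `c1ccc2c(c1)CN[C@@H](CN(CCCN1CCN(C3CC3)CC1)[C@H]1CCCc3cccnc31)C2`, differs from compound 2 by (4-cyclopropylpiperazin-1-yl)methyl in place of piperidin-3-yl on a saturated chain carbon, two bonds along the chain from an amine nitrogen. For the measured compounds named here, no measured step touches this part of the molecule, so the one known step gives no guide to the replacement. Compound 3 is therefore expected to stay near compound 2, an expected step of a number 5 percentage points lower from compound 2 to compound 3 (within the scatter). The estimate for compound 3 in this assay is 70%, expected to fall between 45% and 90%.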

Compound 3, percent of the compound remaining: 21%
Estimate against measurement, compound 3: 49 percentage points above, and the stated range ends above it.
By their numbers in this assay, from the lowest: compound 3; then compound 2; then compound 1.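

Replacing piperidin-3-yl with (4-cyclopropylpiperazin-1-yl)methyl on this saturated chain carbon gives a number 54 percentage points lower from compound 2 to compound 3 (beyond the scatter) and a number 72 percentage points lower from compound 1 to compound 3 (beyond the scatter) in this assay. Both steps are much larger than the change of configuration alone, a number 18 percentage points lower from compound 1 to compound 2 (beyond the scatter), so the choice of group at this position counts for more here than the drawn configuration of the piperidine. Nothing at hand explains the loss.

The change swaps the ring, adds a cyclopropyl and lengthens the arm all at once, so the compounds do not show which of these carries the loss. They also leave open whether a methyl in place of the cyclopropyl, or a morpholine in place of the piperazine, would fare any better.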